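Dimethylamino in Place of Acetyl: Cytotoxicity Outlook for Compound 4

The source may report more compounds than this note shows. Statements on the series, on what has been measured and on what is new or still open speak of the compounds shown alone.

Compound 3 `CC(=O)c1ccc(NC(=O)/C=C/[C@H]2C[C@@H](O)[C@@H](O)C2)cc1` shares its core with compound 1 `O=C(/C=C/[C@H]1C[C@@H](O)[C@@H](O)C1)Nc1ccc(F)cc1` and compound 2 `Cc1ccc(NC(=O)/C=C/[C@H]2C[C@@H](O)[C@@H](O)C2)cc1`. In an ADME assay on S2 cells (Drosophila melanogaster) for cytotoxicity, read by MTT assay (a lower number here means that less compound is needed, a higher number that more compound is needed for the effect), compound 3 gives > 180000 nM, which is a limit of the assay and not a number. Compound 1 gives > 180000 nM, also a limit. Compound 2 gives > 190000 nM, again a limit. The steps a step that the two limits leave unreadable from compound 1 to compound 2, a step that the two limits leave unreadable from compound 1 to compound 3 and a step that the two limits leave unreadable from compound 2 to compound 3 therefore cannot be read in size. Compound 4 `CN(C)c1ccc(NC(=O)/C=C/[C@H]2C[C@@H](O)[C@@H](O)C2)cc1` differs from compound 3 by dimethylamino in place of acetyl on an aromatic carbon. Among the compounds with values here, no measured step offers guidance, since all three values sit at limits (the limit of > 180000 nM in this assay, at which 2 of the 3 values shown sit, and (the limit of > 190000 nM in this assay, at which 1 of the 3 values shown sits)). Compound 4 is accordingly expected to remain at the limit, with a number no higher from compound 3 to compound 4 (the limit leaves the size open) estimated as no readable change. The estimate for compound 4 is 180000 nM, ranging from 90000 nM to 400000 nM.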

Compound 4, half-maximal effective concentration: > 170000 nM
Compound 4 gave a limit, no number; the forecaster's own chance of this, stated with the estimate: 85%; the middle value does not contradict the limit.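

Compound 4, like compound 1, compound 2 and compound 3, gives only a limit in this assay, so its steps to these three compounds cannot be read. The compounds shown leave open what concentration any of the four needs for the effect.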